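The source may hold more compounds than are shown below. What is called first, only, known or untested is meant among the compounds shown, and "the series" means these compounds.

Measured so far:
Compound 1, `CC(=O)NCCN(C)c1cccc(OCCCCCCOc2cccc(OC(=O)NC3CCCCC3)c2)c1`, gives 0.71 in a functional assay on cells for agonist activity at melatonin receptor type 1B (Homo sapiens), read by GTPgammaS binding, with a stated time of 30 min; on this read-out higher numbers stand for larger maximal responses and lower numbers for smaller maximal responses.
Compound 2, `CC(=O)NCCN(C)c1cccc(OCCCCCCOc2cccc(O)c2)c1`, gives 0.57 in this assay.
Compound 3, `CC(=O)NCCN(C)c1cccc(OCCCCOc2cccc(O)c2)c1`, gives 0.18 in this assay.

Compound 1 and compound 2 share one core, and compound 3 and compound 4 share another; the difference between the two cores is not broken down here. Within the first pair the change is cyclohexylcarbamoyl in place of hydrogen on an oxygen on an aromatic ring, and it brought a number 0.14 higher from compound 2 to compound 1 (beyond the scatter). Compound 3 stands lowest of the three measured values in this assay, beyond the scatter from both compound 2 and compound 1.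

Compound 4, `CC(=O)NCCN(C)c1cccc(OCCCCOc2cccc(OC(=O)NC3CCCCC3)c2)c1`, has not yet been measured. It differs from compound 3 by cyclohexylcarbamoyl in place of hydrogen on an oxygen on an aromatic ring, the same change that turned compound 2 into compound 1, made on the same kind of place. Because the earlier step was a number 0.14 higher from compound 2 to compound 1 (beyond the scatter), a step of similar size is expected from compound 3 to compound 4, namely a number 0.14 higher from compound 3 to compound 4 (beyond the scatter). This rests on a single earlier example, made on a different core, so the expected step is held with wide bounds. Compound 4 is therefore estimated to reach 0.32 in this assay, expected to lie between 0.15 and 0.5.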

Compound 4, intrinsic activity: the largest response reached, as a fraction of the reference agonist's: 0.05
Estimate against measurement, compound 4: 0.27 above; the whole stated range lies above it.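

In this assay, cyclohexylcarbamoyl in place of hydrogen on an oxygen on an aromatic ring gave a number 0.13 lower from compound 3 to compound 4 (beyond the scatter), so the step on this core runs the opposite way to the one seen on the other core, and the two steps differ: the same change on two cores in this assay, a number 0.14 higher (beyond the scatter) from compound 2 to compound 1 and a number 0.13 lower (beyond the scatter) from compound 3 to compound 4, 0.27 apart, beyond the scatter of two such steps

This shows that, in these two pairs, neither the size nor the direction of the change in maximal response carried over from one core to the other, so a step measured on one of these cores gave no safe guide to the step on the other. Among these compounds, it does not show which feature of the two cores lies behind the reversal, and with only two pairs it supports no general rule for the series, nor does it say how the same change would behave on any third core.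

The compounds shown leave open whether a phenylcarbamoyl or a methylcarbamoyl group in place of cyclohexylcarbamoyl would split between the two cores in the same way. They also leave open whether a core with a longer chain would follow compound 1 and compound 2 or compound 3 and compound 4 under this change.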